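Methyl for Phenyl on a Chloropyridine-Bearing Triazole Ether

This account rests on a few compounds, and the source may have more. Where it says the series, first, only, none or still open, it means among the compounds named here.

Measured so far:
Compound 1, `COc1cc(COCc2cn(Cc3cc(-c4ccccc4)cnc3Cl)nn2)cc(OC)c1OC`: 86700 nM
Compound 2, `COc1cc(C2CC(COCc3cn(Cc4cc(-c5ccc(F)cc5)cnc4Cl)nn3)ON2C=O)cc(OC)c1OC`: 45700 nM

In a functional assay on MCF7 cells (Homo sapiens) for cytotoxicity, read by MTT assay, with a stated time of 48 h (on this read-out higher numbers stand for weaker inhibition and lower numbers for stronger inhibition), compound 1 gives 86700 nM, the highest of the two numbers recorded. Compound 2, built on a different central framework, gives 45700 nM in this assay; the gap between the two compounds lies within the scatter, so neither can be called the more or less potent on these data.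

The step from compound 1 to compound 3, `COc1cc(COCc2cn(Cc3cc(C)cnc3Cl)nn2)cc(OC)c1OC`, changes one thing: methyl in place of phenyl on an aromatic carbon. The ring that leaves sits two atoms from the ring nitrogen and para to the chloro group, and only a methyl takes its place.

Among the compounds with values here, no measured pair shows what this exchange does. Compound 3 is therefore expected to land close to compound 1, with any shift leaning toward a higher number, as a 1.4-fold higher number from compound 1 to compound 3 (0.14 log units; within the scatter). The estimate for compound 3 in this assay is 120000 nM, between 40000 nM and 350000 nM.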

Compound 3, half-maximal inhibitory concentration: 67400 nM
The estimate for compound 3 lay 1.8-fold (0.25 log units) above the measured number, and the stated range covers the measured number.
By their numbers in this assay, from the lowest: compounds 2, 3 and 1 (each within the scatter of the next).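

In this assay, methyl in place of phenyl on this aromatic carbon, two atoms from the ring nitrogen and para to the chloro group, gives a 1.3-fold lower number from compound 1 to compound 3 (0.11 log units; within the scatter). Methyl can take the place of phenyl at this position without a change that stands clear of the scatter. These two groups cannot be told apart on this read-out. Nothing measured beyond these cytotoxicity numbers bears on why the exchange reads this way.

On these data alone, whether an amine, a carboxylic acid or a longer chain such as propyl on this carbon would move the number beyond the scatter remains open. Also open, as far as these compounds go, is whether the same exchange would read alike on the framework of compound 2.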